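Removing the Difluoromethyl Group from Compound 3

The source may report more compounds than this note shows. Statements on the series, on what has been measured and on what is new or still open speak of the compounds shown alone.

In a functional assay on PANC-1 cells (Homo sapiens), read by microscopy, crystal violet staining and transwell migration, with a stated time of 18 h, in the presence of a further agent that is not named here (a higher number here means a weaker inhibitor, a lower number a stronger inhibitor), compound 1 (`COc1ccc(-c2ncnn2-c2cccc(C(=O)NCCCCc3ccccc3)c2)cc1`) reads > 20000 nM, which is a limit and not a number. Among the measured compounds shown here, compound 2 (`COc1ccc(-c2nc(C3CC3)nn2-c2cccc(C(=O)NCCCCc3ccccc3)c2)cc1`) gives 7680 nM, and compound 3 (`CCc1nc(-c2ccc(OC(F)F)cc2)n(-c2cccc(C(=O)NCCCCc3ccccc3)c2)n1`) gives 830 nM, the lowest number so far. Compound 4 (`CCc1nc(-c2ccc(O)cc2)n(-c2cccc(C(=O)NCCCCc3ccccc3)c2)n1`) differs from compound 3 by hydrogen in place of difluoromethyl on an oxygen on an aromatic ring, or difluoromethoxy to hydroxy. For the measured compounds named here, no measured step covers this change. Going by the values given here, the only one, an at least 2.6-fold lower number from compound 1 to compound 2 (0.41 log units; beyond the scatter), places cyclopropyl on an aromatic carbon, so it shows only that a single swap can move the number beyond the scatter. A weaker result is expected, with a 3.0-fold higher number from compound 3 to compound 4 (0.48 log units; beyond the scatter) as the estimated step. The estimate for compound 4 is 2500 nM, with a range of 600 nM to 12000 nM.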

Compound 4, half-maximal inhibitory concentration: 220 nM
The estimate for compound 4 lay 11-fold (1.06 log units) above the measured number; the measured number lies below the stated range.
By their numbers in this assay, from the lowest: compound 4; then compound 3; then compound 2. At a limit, above all of these: compound 1.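

In this assay, the oxygen on an aromatic ring does not need its difluoromethyl group, since hydrogen in its place gives a lower number (a 3.8-fold lower number from compound 3 to compound 4 (0.58 log units; beyond the scatter)). Among the compounds shown here, this is the first measured change at this position, and the hydroxy in compound 4 reads better than difluoromethoxy, though this rests on a single pair. Nothing measured here explains the shift.

On these data alone, how a methyl or a longer chain on this oxygen, or an amine in place of the hydroxy, would read remains open. So does whether hydroxy gives a similar step alongside the cyclopropyl of compound 2.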